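A few compounds are considered here, and "the series" means these few. Any claim that something is new, unique, unknown or untested is made for them only; others in the source may bear on it.

Compound 1 `N[C@H]1CC[C@H](Nc2c(C(=O)NCc3ccco3)nc(Br)c3cccnc23)CC1` was tested in a functional assay on MDA-MB-435 cells (Homo sapiens) for cytotoxicity, read by MTT assay, with a stated time of 72 h; on this read-out higher numbers stand for weaker inhibition and lower numbers for stronger inhibition. In this assay compound 1 gives > 10000 nM, which is a limit of the assay rather than a number. A second compound, compound 2 `O=C(NCc1ccc(F)cc1)c1nc(Br)c2cccnc2c1NCCCNc1c(C(=O)NCc2ccc(F)cc2)nc(Br)c2cccnc12`, was run in the same way. In this assay compound 2 gives > 20000 nM, again only a limit. So compound 1 stands among two results that are both limits, one of them at the limit of > 10000 nM in this assay, at which 1 of the 2 values shown sits, and the other at the limit of > 20000 nM in this assay, at which 1 of the 2 values shown sits, and no measured step between them can be drawn.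

The next compound, compound 3 `COC(=O)c1nc(Br)c2cccnc2c1N[C@H]1CC[C@H](N)CC1`, is made from compound 1 by a single change at the carbonyl carbon: methoxy in place of ((furan-2-yl)methyl)amino on a carbonyl carbon. Seen one bond further out, the ((furan-2-yl)methyl)carbamoyl group becomes methoxycarbonyl. No comparable step has been measured, so the size of the expected effect cannot be taken from the numbers shown; given that compound 1 sits at a limit, the step is expected to be none beyond the scatter, with a further limit the likeliest outcome. Compound 3 is therefore expected to give about 15000 nM, within 5000 nM to 40000 nM, a step that the limit leaves unreadable from compound 1 to compound 3.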

Compound 3, half-maximal inhibitory concentration: > 20000 nM
Compound 3 was reported as a limit (the forecaster's own chance of this, stated with the estimate: 70%); at least 1.3-fold (0.12 log units) between middle value and limit.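

Compound 1 and compound 3 are both reported only as limits in this assay, so no step can be read between them. Compound 3 shares its limit with one other compound: the limit of > 20000 nM in this assay, at which 2 of the 3 values shown sit. The compounds shown leave open whether methoxy or ((furan-2-yl)methyl)amino on a carbonyl carbon makes any difference to the read-out.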